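The source may report more compounds than this note shows. Statements on the series, on what has been measured and on what is new or still open speak of the compounds shown alone.

Compound 1 `OC[C@H]1O[C@@H](n2cnc3c(NN4CCCC4)ncnc32)[C@H](O)[C@@H]1O` and compound 2 `OC[C@H]1O[C@@H](n2cnc3c(NN4CCCCC4)ncnc32)[C@H](O)[C@@H]1O` share a core carrying a cyclic amine on the exocyclic nitrogen, and in an assay on membranes from brain for binding affinity to adenosine receptor A1 (Rattus norvegicus) (a higher number here means a weaker inhibitor, a lower number a stronger inhibitor), compound 1 gives 8 nM; 8 nM (2 entries) while compound 2 gives 7.3 nM. These two values lie within the scatter of each other. Compound 3 `OC[C@H]1OC(n2cnc3c(NN4CCOCC4)ncnc32)[C@H](O)[C@@H]1O`, with a morpholin-4-yl group in that position, gives 15500 nM in this assay, the highest number of the set; its nearest neighbour is compound 2, and the gap between them lies far beyond the scatter.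

Compound 4 `CC(C)C[C@H](CO)Nc1ncnc2c1ncn2C1O[C@H](CO)[C@@H](O)[C@H]1O` differs from compound 3 in one place: 1-(hydroxymethyl)-3-methylbutyl in place of morpholin-4-yl on a nitrogen on an aromatic ring. The ring with two hetero atoms is gone, and the group that enters brings one hydrogen-bond donor and one defined stereocentre, attached directly through a single nitrogen to the aromatic carbon. Because compound 3 gives 15500 nM while the open-chain and cyclic amine analogues compound 1 and compound 2 sit near 7.3 nM, a large step toward a lower number is expected a 520-fold lower number from compound 3 to compound 4 (2.71 log units; beyond the scatter). Compound 4 is therefore estimated at 30 nM, within a range from 5 nM to 300 nM.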

Compound 4, inhibition constant: 224 nM
Compound 4: middle estimate off by 7.5-fold (0.87 log units), on the low side; measured number inside the range.
By their numbers in this assay, from the lowest: compound 2; then compound 4; then compound 3.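

Putting 1-(hydroxymethyl)-3-methylbutyl in place of morpholin-4-yl on this nitrogen on an aromatic ring gives, in this assay, a 69-fold lower number from compound 3 to compound 4 (1.84 log units; beyond the scatter), a large step beyond the scatter. The earlier compounds shown here all carried a ring on this position, whereas this result shows that a group with no ring, bringing a hydrogen-bond donor and a defined stereocentre, can stand here with a much lower number than compound 3. Nothing measured in the data explains the size of this step.

The compounds shown leave open how much of the step belongs to the hydroxymethyl group and how much to the branched carbon chain, as both enter together. A plain 3-methylbutyl chain, a carboxylic acid in place of the hydroxyl, or the opposite configuration at the stereocentre would each separate these parts.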